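Thiazole Aryl Group Exchange Toward a Methylphenyl Analogue

The source may report more compounds than this note shows. Statements on the series, on what has been measured and on what is new or still open speak of the compounds shown alone.

This account follows a series of compounds sharing one core and differing only in the aryl group on the five-membered aromatic ring with 1 nitrogen and 1 sulfur. Compound 1 `Cc1nc(-c2ccsc2)sc1COc1ccc2c(c1)OCC2CC(=O)O` carries a thiophen-3-yl group there, and in a functional assay on CHO cells for agonist activity at Free fatty acid receptor 1 (Homo sapiens), read by FLIPR and calcium flux (a higher number here means that more compound is needed for the effect, a lower number that less compound is needed), compound 1 gives 68.5 nM. Compound 2 `Cc1nc(-c2ccc(Cl)s2)sc1COc1ccc2c(c1)OCC2CC(=O)O` carries a chlorothiophene group, and for compound 2 the result in this assay is "not determined" (no result reported). Compound 3 `Cc1nc(-c2cc3ccccc3o2)sc1COc1ccc2c(c1)OCC2CC(=O)O` carries the 1-benzofuran-2-yl group; for compound 3 the entry in this assay is likewise "not determined" (no result reported), so it stands without a measured value, as does one further member of the set, compound 2.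

Compound 4 `Cc1ccc(-c2nc(C)c(COc3ccc4c(c3)OCC4CC(=O)O)s2)cc1` differs from compound 3 in one place: 4-methylphenyl in place of 1-benzofuran-2-yl on an aromatic carbon. For the measured compounds named here, no measured step between two compounds of this set is available, so the size of the change in this assay cannot be anchored on a neighbouring pair; the only measured point, compound 1, suggests the core itself supports activity in this range. The author therefore expects compound 4 in this assay to remain near compound 1, with no confident direction.

Compound 4 is estimated at 80 nM, within a range of 25 nM to 250 nM.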

Compound 4, half-maximal effective concentration: 73.5 nM
Beside the measured number, compound 4's estimate is 1.1-fold (0.04 log units) above it; the measured number falls inside the stated range.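

In this assay, for the compounds shown here, 4-methylphenyl in place of thiophen-3-yl on this aromatic carbon gives a 1.1-fold higher number from compound 1 to compound 4 (0.03 log units; within the scatter) and this is the first measured step in the set. The position, next to the ring nitrogen and next to the ring sulfur, therefore carries either group with no step beyond the scatter, and a six-membered aromatic ring of carbon only is accepted here. Nothing measured explains this result.

The steps that involve compound 2 or compound 3 cannot be read, so the chlorothiophene and 1-benzofuran-2-yl groups remain unplaced against these two aryl groups. From the compounds shown here alone, it also remains open whether an amine or a carboxylic acid on the phenyl ring, or a longer chain in place of its methyl group, would keep activity at this level.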